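Central aryl exchange on two cores, antiproliferative read-out

A few compounds are considered here, and "the series" means these few. Any claim that something is new, unique, unknown or untested is made for them only; others in the source may bear on it.

Compound 1 `COc1cc(C=C(C(=O)/C=C/c2cccc(OC)c2OC)C(=O)/C=C/c2cccc(OC)c2OC)cc(OC)c1O` and compound 2 `COc1ccc(C=C(C(=O)/C=C/c2cccc(OC)c2OC)C(=O)/C=C/c2cccc(OC)c2OC)cc1O` share one core; compound 3 `COc1ccc(OC)c(/C=C/C(=O)C(=Cc2cc(OC)c(O)c(OC)c2)C(=O)/C=C/c2cc(OC)ccc2OC)c1` and the as yet unmeasured compound 4 `COc1ccc(OC)c(/C=C/C(=O)C(=Cc2ccc(OC)c(O)c2)C(=O)/C=C/c2cc(OC)ccc2OC)c1` share another. The difference between the two cores is not broken down here; compound 1 and compound 3 are built from the same atoms joined differently. In a functional assay on SW480 cells (Homo sapiens) for antiproliferative activity, read by sulforhodamine B assay, with a stated time of 48 h (on this read-out lower numbers stand for stronger inhibition and higher numbers for weaker inhibition), compound 1 gives 420 nM, compound 2 gives 320 nM, and compound 3 gives 500 nM; all three numbers lie within the scatter of one another.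

The change from compound 1 to compound 2 is 3-hydroxy-4-methoxyphenyl in place of 4-hydroxy-3,5-dimethoxyphenyl on a double-bonded chain carbon bound to a double-bonded chain carbon. Its step is a 1.3-fold lower number from compound 1 to compound 2 (0.12 log units; within the scatter). The change from compound 3 to compound 4 is 3-hydroxy-4-methoxyphenyl in place of 4-hydroxy-3,5-dimethoxyphenyl on a double-bonded chain carbon bound to a double-bonded chain carbon, the same change at the same place, now made on the core of compound 3.

Among the compounds with values here, for compound 4 in this assay the step is expected to be about as small, a 1.3-fold lower number from compound 3 to compound 4 (0.12 log units; within the scatter), because the only measured instance of this change, a 1.3-fold lower number from compound 1 to compound 2 (0.12 log units; within the scatter), stayed within the scatter; whether the core of compound 3 carries it the same way is not known from these three compounds alone. Compound 4 is therefore estimated at 380 nM, with a likely range from 200 nM to 750 nM.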

Compound 4, half-maximal inhibitory concentration: 1120 nM
The estimate for compound 4 lay 2.9-fold (0.47 log units) below the measured number; the measured number lies above the stated range.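

In this assay, putting 3-hydroxy-4-methoxyphenyl in place of 4-hydroxy-3,5-dimethoxyphenyl gives a 2.2-fold higher number from compound 3 to compound 4 (0.35 log units; beyond the scatter), so the exchange does not carry over unchanged from one core to the other: the same change on two cores in this assay, a 1.3-fold lower number (0.12 log units; within the scatter) from compound 1 to compound 2 and a 2.2-fold higher number (0.35 log units; beyond the scatter) from compound 3 to compound 4, 2.9-fold (0.47 log units) apart, beyond the scatter of two such steps

For these two cores, the outcome of this exchange therefore depends on the core that carries it, and the step on the core of compound 1 is no reliable guide to the step on the core of compound 3. The result does not show which feature of the two cores produces the difference, and it rests on a single pair per core, with a modest step on the core of compound 3, so it gives no general rule for the series.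

As far as these compounds go, it remains open whether other exchanges at this place, on a double-bonded chain carbon bound to a double-bonded chain carbon, also diverge between the two cores, or whether the divergence is confined to this pair of aryl groups. A phenyl ring bearing an amine or a carboxylic acid in place of the hydroxy group would test how far the core dependence extends beyond the hydroxy- and methoxy-substituted rings shown here.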